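Pyridin-3-yl for hydroxymethyl on a benzoyl-substituted amide

The source may hold more compounds than are shown below. What is called first, only, known or untested is meant among the compounds shown, and "the series" means these compounds.

Of the compounds shown here, two from this series have been measured in a physicochemical assay for lipophilicity, read by HPLC, measured as octanol-water partition, at pH 2; on this read-out lower numbers stand for lower lipophilicity and higher numbers for higher lipophilicity. Compound 1 `c1cc2ccc(CN3CCCCC3)ccc-2c1` gives 0.8, and compound 2 `O=C(NCCO)c1ccc2ccc(C(=O)c3ccccc3)c-2cc1` gives 2.3, the higher of the two numbers, standing a step beyond the usual scatter above compound 1. Compound 3 `O=C(NCc1cccnc1)c1ccc2ccc(C(=O)c3ccccc3)c-2cc1` has not yet been measured in this assay. It differs from compound 2 in one place: pyridin-3-yl in place of hydroxymethyl on a saturated chain carbon bound to an amide-type nitrogen. Going by the values given here, no measured pair in this set shows the same change, so nothing measured reports its size directly. Taking the low reading of compound 1 together with the higher reading of compound 2 as the only anchors, the estimated step of a number 1.10 log units lower from compound 2 to compound 3 (beyond the scatter) is expected to point downward and to exceed the scatter. Compound 3 is therefore estimated at 1.2, with a likely range from 0.3 to 2.1.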

Compound 3, distribution coefficient: 1.4
For compound 3 the middle estimate is 0.20 log units below the measured one, and the stated range covers the measured number.
By their numbers in this assay, from the lowest: compound 1; then compound 3; then compound 2.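

Placing pyridin-3-yl in place of hydroxymethyl on a saturated chain carbon bound to an amide-type nitrogen gives, in this assay, a reading a number 0.90 log units lower from compound 2 to compound 3 (beyond the scatter). This shows that a single change at this place on the amide side chain can move the read-out past the usual scatter. Here, the group with an aromatic ring and without a hydrogen-bond donor goes with the lower number, not the higher one. Nothing in the data shown accounts for the direction or size of this step.

One step at one place cannot separate the role of the ring nitrogen from that of the ring as a whole. Going by these compounds, it remains open whether a phenyl, a dimethylamino group or a carboxylic acid on the same chain carbon would move the reading in the same direction, and whether a longer chain would change the step.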